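Replacing 2-chloro-4-fluorophenyl with 4-methoxyphenyl on a shared core

This account rests on a few compounds, and the source may have more. Where it says the series, first, only, none or still open, it means among the compounds named here.

In a functional assay on A549 cells (Homo sapiens) for cytotoxicity, read by MTT assay, with a stated time of 72 h (on this read-out higher numbers stand for weaker inhibition and lower numbers for stronger inhibition), compound 1 `COc1cc(/C=C/C(=O)Nc2cc3c(Nc4ccc(F)c(Cl)c4)ncnc3cc2O[C@H]2CCOC2)cc(OC)c1OC` gives 4150 nM, compound 2 `COc1cc(/C=C/C(=O)Nc2cc3c(Nc4ccc(F)c(Cl)c4)ncnc3cc2O[C@H]2CCOC2)cc(OC)c1O` gives 27000 nM, and compound 3 `O=C(/C=C/c1ccc(F)cc1Cl)Nc1cc2c(Nc3ccc(F)c(Cl)c3)ncnc2cc1O[C@H]1CCOC1` gives 5190 nM. Compound 3 thus stands level with compound 1 within the scatter and clearly lower than compound 2. Compound 4 `COc1ccc(/C=C/C(=O)Nc2cc3c(Nc4ccc(F)c(Cl)c4)ncnc3cc2O[C@H]2CCOC2)cc1` differs from compound 3 by 4-methoxyphenyl in place of 2-chloro-4-fluorophenyl on a double-bonded chain carbon bound to a double-bonded chain carbon. Going by the values given here, the closest precedent is a 1.3-fold higher number from compound 1 to compound 3 (0.10 log units; within the scatter), an exchange of groups at the same place. The larger steps, a 6.5-fold higher number from compound 1 to compound 2 (0.81 log units; beyond the scatter) and a 5.2-fold lower number from compound 2 to compound 3 (0.72 log units; beyond the scatter), both involve compound 2, which has hydrogen in place of methyl on an oxygen on an aromatic ring, and compound 4 keeps that methyl. No change beyond the scatter is therefore expected, and the expected step is a 1.0-fold lower number from compound 3 to compound 4 (0.02 log units; within the scatter). For compound 4 the estimated value is 5000 nM, within an expected range of 2000 nM to 13000 nM.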

Compound 4, half-maximal inhibitory concentration: 3050 nM
Compound 4: the middle estimate sits 1.6-fold (0.21 log units) above what was measured; low and high end bracket the measured number.
By their numbers in this assay, from the lowest: compounds 4, 1 and 3 (each within the scatter of the next); then compound 2.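

In this assay the 4-methoxyphenyl group of compound 4 stands level with the 2-chloro-4-fluorophenyl group of compound 3 (a 1.7-fold lower number from compound 3 to compound 4 (0.23 log units; within the scatter)) and with the 3,4,5-trimethoxyphenyl group of compound 1 (a 1.4-fold lower number from compound 1 to compound 4 (0.13 log units; within the scatter)). Three differently substituted phenyl rings at this place therefore read alike, and compound 2, the only one of the four with a hydroxy group, goes against this (an 8.9-fold lower number from compound 2 to compound 4 (0.95 log units; beyond the scatter)).

From the compounds shown here alone, whether a dimethylamino group or a carboxylic acid on this phenyl ring would read like the methoxy group or like the hydroxy group remains open. Nothing available explains why compound 2 stands apart.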